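Fluoro to Chloro on the Ketone-Side Ring

A few compounds are considered here, and "the series" means these few. Any claim that something is new, unique, unknown or untested is made for them only; others in the source may bear on it.

Measured so far:
- compound 1, `O=C(/C=C/c1cc(Br)cc(Br)c1Oc1c([N+](=O)[O-])cc(C(F)(F)F)cc1[N+](=O)[O-])c1ccc(F)cc1`, 8.06 ug/mL
- compound 2, `O=C(/C=C/c1cc(Cl)cc(Cl)c1Oc1c([N+](=O)[O-])cc(C(F)(F)F)cc1[N+](=O)[O-])c1ccc(F)cc1`, 5.02 ug/mL
- compound 3, `O=C(/C=C/c1cc(Br)cc(Br)c1Oc1c([N+](=O)[O-])cc(C(F)(F)F)cc1[N+](=O)[O-])c1ccc(Cl)cc1`, 6.76 ug/mL

All three were tested in a functional assay on MCF7 cells (Homo sapiens) for antiproliferative activity, read by MTT assay, with a stated time of 48 h; a higher number here means a weaker inhibitor, a lower number a stronger inhibitor. Compound 1 gives 8.06 ug/mL, compound 2 gives 5.02 ug/mL and compound 3 gives 6.76 ug/mL. Compound 3 is compound 1 with one change, (chloro in place of fluoro on an aromatic carbon), and this change makes a 1.2-fold lower number from compound 1 to compound 3 (0.08 log units; within the scatter). Compound 2 has a different core from compound 1, and the difference between the two cores is not broken down here; the values of compound 1 and compound 2 lie within the usual scatter of each other, so no order between them can be read.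

Compound 4, `O=C(/C=C/c1cc(Cl)cc(Cl)c1Oc1c([N+](=O)[O-])cc(C(F)(F)F)cc1[N+](=O)[O-])c1ccc(Cl)cc1`, has not yet been measured. It is compound 2 with the same change, (chloro in place of fluoro on an aromatic carbon), that turns compound 1 into compound 3: the two place descriptions agree word for word, so it is the same change made on the other core.

Among the compounds with values here, the one example already measured, from compound 1 to compound 3, stayed within the scatter, so the expectation for compound 4 rests on that step and on the value of compound 2. The step from compound 2 to compound 4 is estimated as a 1.1-fold lower number from compound 2 to compound 4 (0.05 log units; within the scatter), with the direction taken from a 1.2-fold lower number from compound 1 to compound 3 (0.08 log units; within the scatter) and the size kept small because a 1.2-fold lower number from compound 1 to compound 3 (0.08 log units; within the scatter) was itself small. Compound 4 is therefore expected to give about 4.5 ug/mL in this assay, with a likely range from 2.5 ug/mL to 8 ug/mL.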

Compound 4, half-maximal inhibitory concentration: 4.54 ug/mL
The estimate for compound 4 lay 1.0-fold (0.00 log units) below the measured number; measured number inside the range.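

In this assay, chloro in place of fluoro on the core of compound 2 gives a 1.1-fold lower number from compound 2 to compound 4 (0.04 log units; within the scatter), so going from 4-fluorophenyl to 4-chlorophenyl produces no readable shift on this core. Set beside the earlier step, the same change looks alike on the two cores, as far as these numbers can tell: the same change on two cores in this assay, a 1.2-fold lower number (0.08 log units; within the scatter) from compound 1 to compound 3 and a 1.1-fold lower number (0.04 log units; within the scatter) from compound 2 to compound 4, 1.1-fold (0.03 log units) apart, within the scatter of two such steps. This shows that the swap carried over from one core to the other without any visible surprise, but it does not show a real gain or loss from the change on either core, and two cores give no assurance about a third.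

The compounds shown leave open what other groups would do at this place on the ring, such as a methoxy group, a nitrile or an amine, and whether any of them would move the number beyond the scatter. On these data alone, it also remains open whether the swap from fluoro to chloro would look the same in a different cell line.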